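The compounds below may be only part of what the source reports. "The series", "measured", "known", "first", "only" and "open" are said of these compounds alone.

Compound 1, `O=c1[nH]c(=O)n(CCC(CO)CO)cc1-c1cccs1`: in a functional assay on SW-620 cells (Homo sapiens) for antiproliferative activity, read by MTT assay, with a stated time of 72 h (on this read-out lower numbers stand for stronger inhibition and higher numbers for weaker inhibition), compound 1 gives > 100000 nM, a limit of the assay rather than a number.
Compound 2, `O=c1[nH]c(=O)n(CCC(CO)CO)cc1C#Cc1ccc(Br)cc1`: in this assay compound 2 gives > 100000 nM, again a limit of the assay and not a number.
Compound 3, `O=c1[nH]c(=O)n(CCC(CO)CO)cc1C#CCc1ccccc1`: in this assay compound 3 gives 72400 nM.

Among the measured compounds shown here, compound 3 therefore holds the only actual number among the three; the other two results are limits, as the line the limit of > 100000 nM in this assay, at which 2 of the 3 values shown sit, shows. Compound 4, `CCCCCC#Cc1cn(CCC(CO)CO)c(=O)[nH]c1=O`, has not yet been measured. It differs from compound 3 by butyl in place of phenyl on a saturated chain carbon bound to a triple-bonded carbon, so that the benzyl on the triple-bonded carbon becomes a pentyl. For the measured compounds named here, the one measured step that touches this part of the molecule is the exchange of the group on the triple-bonded carbon, an at least 1.3-fold lower number from compound 2 to compound 3 (0.14 log units; that floor lies within the scatter), and that step stays within the scatter of repeated measurements. Going by the values given here, no measured step shows what happens when the ring is removed altogether. On this evidence no movement beyond the scatter is expected for compound 4, with the open chance that the assay again reports only a limit. Compound 4 is expected to give about 90000 nM in this assay, with a likely span from 30000 nM to 300000 nM, which means an expected step of a 1.2-fold higher number from compound 3 to compound 4 (0.09 log units; within the scatter).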

Compound 4, half-maximal inhibitory concentration: > 100000 nM
Compound 4 was reported as a limit (the forecaster's own chance of this, stated with the estimate: 50%); middle value at least 1.1-fold (0.04 log units) from the limit.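

Butyl in place of phenyl on a saturated chain carbon bound to a triple-bonded carbon gives an at least 1.3-fold higher number from compound 3 to compound 4 (0.14 log units; that floor lies within the scatter). Among the compounds shown here, this is the first test of a chain without a ring in this place, and it brings no gain, although the size of any loss cannot be told. For the compounds shown here, compound 4 stands at a limit, not a number, like compound 1 and compound 2, so the steps from those two to compound 4 cannot be read, and compound 3 keeps the only actual number in this assay: the limit of > 100000 nM in this assay, at which 3 of the 4 values shown sit.

Going by these compounds, whether the phenyl of compound 3 truly matters stays open, as the floor of this step lies within the scatter. Also open, on these data alone, is what a longer chain, or an amine in place of the benzyl, would do on the triple-bonded carbon.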